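The compounds below may be only part of what the source reports. "The series", "measured", "known", "first", "only" and "open" are said of these compounds alone.

Measured compounds:
- compound 1 `O=C(Nc1cccc(-n2cc(-c3ccncc3)c(-c3ccc(Cl)c(O)c3)n2)c1)Nc1cccc(C(F)(F)F)c1` — 1460 nM in a functional assay on NCI-H522 cells (Homo sapiens) for inhibition, read by sulforhodamine B assay, with a stated time of 48 h; on this read-out higher numbers stand for weaker inhibition of growth and lower numbers for stronger inhibition of growth
- compound 2 `O=C(Nc1cccc(-n2cc(-c3ccncc3)c(-c3ccc(Cl)c(O)c3)n2)c1)Nc1cc(C(F)(F)F)cc(C(F)(F)F)c1` — 724 nM

Compound 1 holds the highest of the two numbers in this assay; its nearest neighbour is compound 2, reached by a trifluoromethyl in place of hydrogen on an aromatic carbon, with a 2.0-fold lower number from compound 1 to compound 2 (0.30 log units; within the scatter). For the measured compounds named here, that is the only step available, and it lies within the scatter.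

Compound 3 `O=C(Nc1cccc(-n2cc(-c3ccncc3)c(-c3ccc(Cl)c(O)c3)n2)c1)Nc1ccc(Cl)c(C(F)(F)F)c1` is not yet measured. Its change from compound 1 is chloro in place of hydrogen on an aromatic carbon. Going by the values given here, no step involving chloro on this ring has been measured, so the only guide is the step from compound 1 to compound 2, where a further substituent on the same ring, with a 2.0-fold lower number from compound 1 to compound 2 (0.30 log units; within the scatter), moved the number by less than the scatter. The change to compound 3 is of the same general kind, a single added group on that ring, and is expected to behave much the same: a small shift, if any, most likely downward, with a 1.5-fold lower number from compound 1 to compound 3 (0.16 log units; within the scatter).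

Compound 3 is therefore estimated at 1000 nM in this assay, with a range of 400 nM to 2500 nM.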

Compound 3, concentration for 50% growth inhibition: 720 nM
Compound 3: middle estimate off by 1.4-fold (0.14 log units), on the high side, and the stated range covers the measured number.
By their numbers in this assay, from the lowest: compounds 3, 2 and 1 (each within the scatter of the next, the first and the last beyond it).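

In this assay, the position ortho to the trifluoromethyl group and para to a large group accepts chloro in place of hydrogen, with a 2.0-fold lower number from compound 1 to compound 3 (0.31 log units; beyond the scatter). This gives the series a step on the 3-(trifluoromethyl)phenyl ring that lies beyond the scatter, although only modestly, whereas the trifluoromethyl change gave a 2.0-fold lower number from compound 1 to compound 2 (0.30 log units; within the scatter), which stays within it. The move from 3-(trifluoromethyl)phenyl to 4-chloro-3-(trifluoromethyl)phenyl thus lowers the number without any other part of compound 1 changing, but a single step of this size supports no trend, and there is no independent measurement that bears on why the number moves.

The compounds shown leave open whether the shift is specific to chloro or would also appear with fluoro, methyl, methoxy or an amine at the same position. They also leave open whether chloro gives a similar step when the trifluoromethyl group is replaced, for instance by a methyl group or a nitrile, since both compounds in this step carry trifluoromethyl.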